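Working notes on the step from compound 3 to compound 4

This account rests on a few compounds, and the source may have more. Where it says the series, first, only, none or still open, it means among the compounds named here.

Measured so far in a functional assay on CHO cells for agonist activity at metabotropic glutamate receptor 1 (Rattus norvegicus), read by calcium flux; on this read-out lower numbers stand for an effect already at smaller amounts and higher numbers for an effect only at larger amounts of compound:
compound 1 `CCc1c(C(N)C(=O)O)cnn1O` gives > 1000000 nM, a limit of the assay.
compound 2 `CCCCc1c(C(N)C(=O)O)cnn1O` gives > 1000000 nM, a limit of the assay.
compound 3 `CCCCCc1c(C(N)C(=O)O)cnn1O` gives > 1000000 nM, a limit of the assay.

Compound 3 stands together with compounds 1 and 2 at the limit (the limit of > 1000000 nM in this assay, at which 3 of the 3 values shown sit); none of the three has a number of its own in this assay. The steps among them, a step that the two limits leave unreadable from compound 1 to compound 2, a step that the two limits leave unreadable from compound 1 to compound 3 and a step that the two limits leave unreadable from compound 2 to compound 3, are therefore not readable in size or direction: lengthening the chain leaves every member at the limit.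

Compound 4 `NC(C(=O)O)c1cnn(O)c1Cc1ccccc1` is not yet measured. It differs from compound 3 in that (phenyl in place of butyl on a saturated chain carbon bound to an aromatic carbon). The measured steps bear on it only in a weak way: every chain tried so far sits at the limit, and none shows whether a change at this chain carbon moves the read-out at all. The expectation for compound 4 is that a number no higher from compound 3 to compound 4 (the limit leaves the size open) in this assay, that is, no readable movement away from the limit. The estimate for compound 4 in this assay is 1000000 nM, with a range from 200000 nM to 5000000 nM, and the assay is expected most likely to report a limit again.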

Compound 4, half-maximal effective concentration: > 1000000 nM
Compound 4: only a limit was reported; the forecaster's own chance of this, stated with the estimate: 80%; the middle value lies on the limit itself.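

In this assay, among the compounds shown here, compound 4 gives > 1000000 nM, which is a limit of the assay, so no step from compound 1, compound 2 or compound 3 to compound 4 can be read. All four compounds stand together: the limit of > 1000000 nM in this assay, at which 4 of the 4 values shown sit.

The compounds shown leave open whether any change at this chain carbon moves the read-out at all.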